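Notes on compound 3 and its butyl analogue

This account rests on a few compounds, and the source may have more. Where it says the series, first, only, none or still open, it means among the compounds named here.

Going by the values given here, in an ADME assay on Caco-2 cells (Homo sapiens) for permeability, read by LC-MS, in the apical to basolateral direction, with a stated time of 60 min, at pH 6.5 (a higher number here means that the compound crosses the layer faster, a lower number that the compound crosses the layer more slowly), compound 3 `CC(C)(C)C[C@@H](O)C(=O)N1N=CC[C@H]1C(=O)NCc1cc(Cl)ccc1-n1cnnn1` gives 24 10^-6 cm/s, the highest number of the three measured so far. Compound 1 `O=C(NCc1cc(Cl)ccc1-n1cnnn1)[C@@H]1CC=NN1C(=O)[C@H](O)c1ccccc1F` gives 8.9 10^-6 cm/s and compound 2 `CC1(C[C@@H](O)C(=O)N2N=CC[C@H]2C(=O)NCc2cc(Cl)ccc2-n2cnnn2)CC1` gives 9.5 10^-6 cm/s, and these two do not separate: a 1.1-fold higher number from compound 1 to compound 2 (0.03 log units; within the scatter). The next compound, compound 4 `CCCC[C@@H](O)C(=O)N1N=CC[C@H]1C(=O)NCc1cc(Cl)ccc1-n1cnnn1`, carries propyl in place of tert-butyl on a saturated chain carbon, two bonds along the chain from a carbonyl carbon and an oxygen on a saturated carbon. Cut one bond further out, this reads neopentyl to butyl.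

The closest measured change at this place involves compound 2, with a modest 2.5-fold higher number from compound 2 to compound 3 (0.40 log units; beyond the scatter). The change involving compound 1 is of similar size, a 2.7-fold higher number from compound 1 to compound 3 (0.43 log units; beyond the scatter), but it exchanges 2-fluorophenyl, a more distant comparison. Among the compounds with values here, no measured compound carries butyl, so the expectation is only a loose one: a lower number, of similar or smaller size than these steps. The expected change is a 1.7-fold lower number from compound 3 to compound 4 (0.23 log units; within the scatter). For compound 4 the estimated value is 14 10^-6 cm/s, with an expected range of 7 10^-6 cm/s to 28 10^-6 cm/s.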

Compound 4, apparent permeability: 9.8 10^-6 cm/s
Compound 4: middle estimate off by 1.4-fold (0.15 log units), on the high side; low and high end bracket the measured number.
By their numbers in this assay, from the lowest: compounds 1, 2 and 4 (each within the scatter of the next); then compound 3.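

Replacing tert-butyl with propyl at this place gives a 2.4-fold lower number from compound 3 to compound 4 (0.39 log units; beyond the scatter), which shows that the higher number of compound 3 does not extend to the straight butyl chain. Compound 4 also falls in with the other two, at a 1.0-fold higher number from compound 2 to compound 4 (0.01 log units; within the scatter) and a 1.1-fold higher number from compound 1 to compound 4 (0.04 log units; within the scatter), so in this assay butyl, (1-methylcyclopropyl)methyl and 2-fluorophenyl do not separate, and neopentyl in compound 3 alone stands apart. No available evidence bears on why this one group differs from the others at this position.

Open, from the compounds shown here alone, is whether the higher number follows a branched chain end in general, a reading that compound 2 already goes against. An isobutyl group, a longer chain, or a chain ending in an amine or a carboxylic acid at this place would test how narrow the neopentyl result is.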